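The source may report more compounds than this note shows. Statements on the series, on what has been measured and on what is new or still open speak of the compounds shown alone.

Compound 3 `O=C(Nc1cccc(-c2nc3ccccc3s2)c1)c1cc([N+](=O)[O-])ccc1Cl` is the parent of the pair under consideration. In an ADME assay on BJ cells (Homo sapiens) for cytotoxicity, with a stated time of 72 h (on this read-out lower numbers stand for an effect already at smaller amounts and higher numbers for an effect only at larger amounts of compound), compound 3 gives only a limit, > 27000 nM. Compound 1 `O=C(Nc1ccc(O)c(-c2nc3ccccc3s2)c1)c1cc([N+](=O)[O-])ccc1Cl` likewise returns a limit, > 25000 nM, in this assay. Compound 2 `COc1cc(Cl)c(C(=O)Nc2cccc(-c3nc4ccccc4s3)c2)cc1[N+](=O)[O-]` also gives a limit of > 25000 nM in this assay. The step that the two limits leave unreadable from compound 1 to compound 3 and the step that the two limits leave unreadable from compound 2 to compound 3 therefore cannot be sized, and compound 3 stands at a limit alongside two further limits. Compound 4 `O=C(Nc1ccc(Cl)c(-c2nc3ccccc3s2)c1)c1cc([N+](=O)[O-])ccc1Cl` differs from compound 3 by chloro in place of hydrogen on an aromatic carbon. For the measured compounds named here, no measured step covers this change, and the two that touch compound 3 are unreadable because of the limit of > 25000 nM in this assay, at which 2 of the 3 values shown sit, and (the limit of > 27000 nM in this assay, at which 1 of the 3 values shown sits), so nothing beyond the scatter is expected in this assay. Compound 4 is expected to give 30000 nM (range 10000 nM to 100000 nM). That corresponds to an expected step that the limit leaves unreadable from compound 3 to compound 4.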

Compound 4, half-maximal effective concentration: > 25000 nM
Compound 4 was reported as a limit (the forecaster's own chance of this, stated with the estimate: 80%); the middle value does not contradict the limit.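

The steps from compound 3 and from compound 1 to compound 4 cannot be read, because these values are limits: the limit of > 25000 nM in this assay, at which 3 of the 4 values shown sit.

The compounds shown leave open whether chloro, hydrogen or hydroxy at this place differ at all in this assay.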